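The compounds below may be only part of what the source reports. "The series", "measured", "known", "first", "only" and "open" are said of these compounds alone.

Values in a functional assay (blood) for inhibition, with Homo sapiens as the target; a lower number here means a stronger inhibitor, a higher number a weaker inhibitor:
- compound 1 `Cc1nc2ccc(COc3ccc4c(c3)c(SC(C)(C)C)c(CC(C)(C)C(=O)O)n4Cc3ccc(Cl)cc3)cc2s1`: > 3000 nM, a limit and not a number
- compound 2 `CC(C)(C)Sc1c(CC(C)(C)C(=O)O)n(Cc2ccc(Cl)cc2)c2ccc(OCc3cccc(Cl)n3)cc12`: 410 nM

Among the compounds with values here, compound 2 holds the only true number in this small set, so it has no measured compound to be ranked against. Within the data shown here, the single measured step is an at least 7.3-fold lower number from compound 1 to compound 2 (0.86 log units; beyond the scatter), which is beyond the scatter. It shows that the group on the saturated chain carbon bound to an oxygen on an aromatic ring can move the number in this assay by a clear margin.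

Compound 3 `C[C@H](COc1ccc2c(c1)c(SC(C)(C)C)c(CC(C)(C)C(=O)O)n2Cc1ccc(Cl)cc1)c1ccccn1` changes that same place: 1-(pyridin-2-yl)ethyl in place of 6-chloropyridin-2-yl on a saturated chain carbon bound to an oxygen on an aromatic ring. Among the measured compounds shown here, no measured compound carries this new group, so the direction is uncertain, although the six-membered aromatic ring with 1 hetero atom stays. The expected change is small, and the estimated step is a 1.5-fold higher number from compound 2 to compound 3 (0.17 log units; within the scatter). Compound 3 is estimated at 600 nM, with an expected range of 150 nM to 2400 nM.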

Compound 3, half-maximal inhibitory concentration: 470 nM
Estimate against measurement, compound 3: 1.3-fold (0.11 log units) above; measured number inside the range.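

Replacing 6-chloropyridin-2-yl with 1-(pyridin-2-yl)ethyl gives a 1.1-fold higher number from compound 2 to compound 3 (0.06 log units; within the scatter), so in this assay these two groups cannot be told apart, although the entering group has no chlorine and brings a defined stereocentre. The same group set against 2-methyl-1,3-benzothiazol-6-yl gives an at least 6.3-fold lower number from compound 1 to compound 3 (0.80 log units; beyond the scatter), so two different groups, each with a six-membered aromatic ring with 1 hetero atom, now stand clear of compound 1. The value of compound 1 is a limit and not a number, so the full size of its steps stays unknown: the limit of > 3000 nM in this assay, at which 1 of the 3 values shown sits.

Going by these compounds, it remains open whether the mirror-image form of 1-(pyridin-2-yl)ethyl would read the same in this assay. On these data alone, it is also open whether a plain phenyl ring, or a pyridine ring carrying an amine, would hold the number at this position.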